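The source may report more compounds than this note shows. Statements on the series, on what has been measured and on what is new or still open speak of the compounds shown alone.

Working notes on the series. The shared core carries an aryl group whose substituent varies. Compound 1 `CCc1ccc(-c2noc(COc3ccc(CCC(=O)O)cc3)n2)cc1` gives 210 nM in a functional assay on CHO cells for agonist activity at Free fatty acid receptor 1 (Homo sapiens), read by FLIPR and calcium flux, in the presence of a further agent that is not named here; on this read-out lower numbers stand for an effect already at smaller amounts and higher numbers for an effect only at larger amounts of compound. Compound 2 `O=C(O)CCc1ccc(OCc2nc(-c3cccs3)no2)cc1` gives 2570 nM, and the step of a 12-fold higher number from compound 1 to compound 2 (1.09 log units; beyond the scatter) is the largest movement seen so far. Compound 3 `O=C(O)CCc1ccc(OCc2nc(-c3ccc(C(F)(F)F)cc3)no2)cc1` gives 610 nM; the step of a 2.9-fold higher number from compound 1 to compound 3 (0.46 log units; beyond the scatter) is smaller. Among the three numbers compound 3 stands second highest, nearer to compound 1 than to compound 2, both gaps beyond the scatter.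

Compound 4 `O=C(O)CCc1ccc(OCc2nc(-c3ccc(Cl)cc3)no2)cc1` is not yet measured. It differs from compound 3 by chloro in place of trifluoromethyl on an aromatic carbon. Going by the values given here, no measured step swaps one small substituent for another on this ring; the only comparable movement is the modest one from compound 1 to compound 3, and the large one to compound 2 involves a different ring altogether. A small step is therefore expected in this assay, most likely toward a lower number, and possibly within the scatter. The expected step is a 1.4-fold lower number from compound 3 to compound 4 (0.13 log units; within the scatter). Compound 4 is estimated at 450 nM, with a range from 150 nM to 1400 nM.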

Compound 4, half-maximal effective concentration: 540 nM
Compound 4: middle estimate off by 1.2-fold (0.08 log units), on the low side; low and high end bracket the measured number.
By their numbers in this assay, from the lowest: compound 1; then compounds 4 and 3 (each within the scatter of the next); then compound 2.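

In this assay chloro in place of trifluoromethyl on the aromatic carbon para to a large group gives a 1.1-fold lower number from compound 3 to compound 4 (0.05 log units; within the scatter) and so does not separate these two substituents, despite 1 heavy atom entering where 4 leave. Ethyl remains apart from chloro, with a 2.6-fold higher number from compound 1 to compound 4 (0.41 log units; beyond the scatter) beyond the scatter and of similar size to a 2.9-fold higher number from compound 1 to compound 3 (0.46 log units; beyond the scatter) in this assay, while a 4.8-fold lower number from compound 2 to compound 4 (0.68 log units; beyond the scatter) places the 4-chlorophenyl compound clearly away from the thiophen-2-yl one. No measurement at hand bears on why these numbers fall as they do.

Going by these compounds alone, whether the ethyl result reflects something particular to that group remains open, as only three substituents on this ring can be compared here. A longer chain such as propyl, a methoxy group or an amine at this position could show whether numbers near that of compound 1 extend beyond ethyl.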